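Glycine Carbamate Analogue in the Paw Edema Series

The source may hold more compounds than are shown below. What is called first, only, known or untested is meant among the compounds shown, and "the series" means these compounds.

Compound 1 `CC(=O)Nc1ccc(O)c(C(=O)OCCn2c([N+](=O)[O-])cnc2C)c1` carries an acetamide on the shared core; in a functional assay on the whole organism (strain Wistar) for inhibition, with Rattus norvegicus as the target, read by paw edema, with stated times of 1 h and 2 h, at a dose of 10 mg/kg by the intraperitoneal route (a lower number here means less inhibition, a higher number more inhibition at the dose given (going by the name of the read-out)), compound 1 gives 24.5%. Compound 2 `Cc1ncc([N+](=O)[O-])n1CCOC(=O)c1cc(NC(=O)[C@H](C)NC(=O)OCc2ccccc2)ccc1O` gives 37.5% and compound 3 `Cc1ncc([N+](=O)[O-])n1CCOC(=O)c1cc(NC(=O)[C@@H](NC(=O)OCc2ccccc2)C(C)C)ccc1O` gives 64.5%. Compound 1 therefore stands lowest of the three, with compound 2 nearest and compound 3 furthest, both beyond the scatter.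

Compound 4 `Cc1ncc([N+](=O)[O-])n1CCOC(=O)c1cc(NC(=O)CNC(=O)OCc2ccccc2)ccc1O` differs from compound 1 by (benzyloxycarbonyl)amino in place of hydrogen on a saturated chain carbon bound to a carbonyl carbon. Among the compounds with values here, no measured step covers this change directly. Within the data shown here, the only step in the set, a number 27 percentage points higher from compound 2 to compound 3 (beyond the scatter), goes the other way along the chain-carbon substituent, from methyl to isopropyl; compound 4 holds hydrogen at that position, smaller than either. Compound 1 and compound 2 bracket what the carbamate-bearing side chain brings without that alkyl.

For compound 4 the expected result is a rise from compound 1, a number 5.5 percentage points higher from compound 1 to compound 4 (within the scatter), landing at or a little under compound 2. Estimated value for compound 4: 30%, range 15% to 48%.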

Compound 4, a percentage reported as inhibition, in the whole organism at one dose (the size of the read-out at that dose, not a potency): 56.5%
Estimate against measurement, compound 4: 26.5 percentage points below, outside the stated range (above it).
By their numbers in this assay, from the lowest: compound 1; then compound 2; then compounds 4 and 3 (each within the scatter of the next).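

In this assay the (benzyloxycarbonyl)amino group in place of hydrogen on a saturated chain carbon bound to a carbonyl carbon is enough on its own for a large gain, a number 32 percentage points higher from compound 1 to compound 4 (beyond the scatter), with no alkyl group on that chain. With hydrogen in place of an alkyl group on the saturated chain carbon bound to an amide-type nitrogen and a carbonyl carbon, the record reads a number 19 percentage points higher from compound 2 to compound 4 (beyond the scatter) and a number 8 percentage points lower from compound 3 to compound 4 (within the scatter), so hydrogen, methyl and isopropyl form no steady rise with the alkyl group, and compound 2 goes against any such trend. No evidence at hand accounts for this result.

Open, on these data alone, is whether ethyl or benzyl on that chain carbon would follow compound 2 or compound 3. Also open, as far as these compounds go, is how a free amine or a tert-butoxycarbonyl group would compare with the (benzyloxycarbonyl)amino group of compound 4.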